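The source may report more compounds than this note shows. Statements on the series, on what has been measured and on what is new or still open speak of the compounds shown alone.

Compound 2, `CCCc1nc(-c2ccccc2)c(CNCCN2CCN(c3ccccc3C)CC2)o1`, gives 51.3% in an assay on HEK293 cells for inhibition of Voltage-dependent T-type calcium channel subunit alpha-1G (Homo sapiens), read by fluorescence, tested at 10 uM (on this read-out lower numbers stand for less inhibition and higher numbers for more inhibition at the one concentration tested (going by the name of the read-out)), the higher of the two numbers at hand; compound 1, `CCCc1nc(-c2ccccc2)c(CNCCN2CCN(c3ccccc3OC)CC2)o1`, gives 39.7%. For the measured compounds named here, the one step between them, a number 11.6 percentage points higher from compound 1 to compound 2 (beyond the scatter), came with methyl in place of methoxy on an aromatic carbon. Compound 3, `CCCc1nc(-c2ccccc2)c(CNCCN2CCN(c3cccc(Cl)c3)CC2)o1`, differs from compound 2 by 3-chlorophenyl in place of 2-methylphenyl on an amine nitrogen in a ring. Going by the values given here, no measured step covers this exchange, and the single step seen was modest, so compound 3 is expected to stay near compound 2, with a change of a number 3.3 percentage points lower from compound 2 to compound 3 (within the scatter) that need not lie beyond the scatter. Compound 3 is therefore estimated at 48%, within 30% to 66%.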

Compound 3, a percentage reported as inhibition, at one concentration (the size of the read-out at that concentration, not a potency): 51.2%
Estimate against measurement, compound 3: 3.2 percentage points below; the measured number falls inside the stated range.
By their numbers in this assay, from the lowest: compound 1; then compounds 3 and 2 (each within the scatter of the next).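

In this assay, 3-chlorophenyl in place of 2-methylphenyl on the amine nitrogen in the ring gives a number 0.1 percentage points lower from compound 2 to compound 3 (within the scatter), so these two groups cannot be told apart at this position. In place of 2-methoxyphenyl, the same group gives a number 11.5 percentage points higher from compound 1 to compound 3 (beyond the scatter), which leaves compound 1 lowest of the three, now against two different groups rather than one. Nothing at hand gives a reason for either step. The compounds shown leave open how an unsubstituted phenyl or a pyridyl group on this nitrogen would read.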